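Amine variation on the shared core: compound 3 to compound 4

A few compounds are considered here, and "the series" means these few. Any claim that something is new, unique, unknown or untested is made for them only; others in the source may bear on it.

Within the data shown here, compound 3 `Cc1nc(-c2cnc(N3CCCCC3)[nH]c2=O)ccc1Oc1ccnc(-c2cnn(C)c2)c1` gives 30 nM in a functional assay on NFS-60 cells (Mus musculus) for antiproliferative activity, read by resazurin assay, with a stated time of 72 h (a lower number here means a stronger inhibitor, a higher number a weaker inhibitor), the lowest of the three numbers measured so far. Compound 2 `Cc1nc(-c2cnc(N3CCCC3)[nH]c2=O)ccc1Oc1ccnc(-c2cnn(C)c2)c1` gives 56 nM in this assay, and compound 1 `Cc1nc(-c2cnc(N(C)C)[nH]c2=O)ccc1Oc1ccnc(-c2cnn(C)c2)c1` gives 716 nM. The step of a 1.9-fold lower number from compound 2 to compound 3 (0.27 log units; within the scatter) is within the scatter, whereas a 13-fold lower number from compound 1 to compound 2 (1.11 log units; beyond the scatter) and a 24-fold lower number from compound 1 to compound 3 (1.38 log units; beyond the scatter) are both large and beyond it, so dimethylamino stands clearly apart from pyrrolidin-1-yl and piperidin-1-yl. Compound 4 `Cc1nc(-c2cnc(NC3CC3)[nH]c2=O)ccc1Oc1ccnc(-c2cnn(C)c2)c1` carries cyclopropylamino in place of piperidin-1-yl on an aromatic carbon. Among the measured compounds shown here, no measured step covers cyclopropylamino or any amine with a hydrogen-bond donor at this position, so the steps that bear on it are indirect: the two large steps from dimethylamino show that this amine matters strongly, and the step of a 1.9-fold lower number from compound 2 to compound 3 (0.27 log units; within the scatter) shows little change across the two cyclic amines. For compound 4 the expected step of a 6.7-fold higher number from compound 3 to compound 4 (0.82 log units; beyond the scatter) is taken as a higher number, because a 24-fold lower number from compound 1 to compound 3 (1.38 log units; beyond the scatter) indicates that moving away from piperidin-1-yl can cost a great deal. The estimate for compound 4 is 200 nM, with a range from 40 nM to 1000 nM.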

Compound 4, half-maximal inhibitory concentration: 55 nM
The estimate for compound 4 lay 3.6-fold (0.56 log units) above the measured number; measured number inside the range.
By their numbers in this assay, from the lowest: compounds 3, 4 and 2 (each within the scatter of the next); then compound 1.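

In this assay, cyclopropylamino puts a hydrogen-bond donor on this aromatic carbon and brings 4 heavy atoms in place of 6, yet a 1.8-fold higher number from compound 3 to compound 4 (0.26 log units; within the scatter) and a 1.0-fold lower number from compound 2 to compound 4 (0.01 log units; within the scatter) both lie within the scatter, so compounds 2, 3 and 4 cannot be told apart here. Compound 1 alone stands apart, with a 13-fold lower number from compound 1 to compound 4 (1.11 log units; beyond the scatter), so among the compounds shown the dimethylamino group is the only one separated from the rest, and neither the ring size nor the amine hydrogen separates the three amines that carry a ring. No measurement is available that accounts for this gap.

Open, on these data alone, is whether an open-chain amine that keeps the amine hydrogen, such as ethylamino, falls with compound 1 or with compounds 2, 3 and 4. Also open, as far as these compounds go, is how a ring with a second hetero atom, such as morpholin-4-yl, would read at this carbon.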